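Swapping methoxy for nitro on an aromatic carbon

This account rests on a few compounds, and the source may have more. Where it says the series, first, only, none or still open, it means among the compounds named here.

Compound 1 `COc1ccc(-n2ccnc2-c2cc(OC)c(OC)c(OC)c2)cc1[N+](=O)[O-]`: 2500 nM
Compound 2 `COc1cccc(-n2ccnc2-c2cc(OC)c(OC)c(OC)c2)c1`: 11000 nM

In a functional assay on HeLa cells (Homo sapiens) for antiproliferative activity, read by MTT assay, with a stated time of 72 h (on this read-out higher numbers stand for weaker inhibition and lower numbers for stronger inhibition), compound 2 gives 11000 nM, the higher of the two numbers, and its gap to compound 1 lies beyond the scatter. Compound 3 `COc1cc(-c2nccn2-c2cccc([N+](=O)[O-])c2)cc(OC)c1OC` has nitro in place of methoxy on an aromatic carbon, meta to a large group: nitro in place of methoxy on an aromatic carbon. Within the data shown here, no measured pair shows this change alone. A moderate step toward a lower number is expected in this assay, since compound 1, which also carries a nitro, gives 2500 nM. The estimated step is a 1.8-fold lower number from compound 2 to compound 3 (0.26 log units; within the scatter). The expected value for compound 3 is 6000 nM, within a range from 2000 nM to 20000 nM.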

Compound 3, half-maximal inhibitory concentration: 6700 nM
Estimate against measurement, compound 3: 1.1-fold (0.05 log units) below, and the stated range covers the measured number.
By their numbers in this assay, from the lowest: compound 1; then compounds 3 and 2 (each within the scatter of the next).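

Read in this assay nitro in place of methoxy on this aromatic carbon, meta to a large group, brings a 1.6-fold lower number from compound 2 to compound 3 (0.22 log units; within the scatter) so here the two groups cannot be told apart. With the nitro kept, dropping the extra methoxy brings a 2.7-fold higher number from compound 1 to compound 3 (0.43 log units; beyond the scatter) a modest step that shows nitro alone does not give the lowest number seen here.

As far as these compounds go, whether an amine or a carboxylic acid on this aromatic carbon would shift the number remains open. Nothing given here offers a reason for either step.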